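This account rests on a few compounds, and the source may have more. Where it says the series, first, only, none or still open, it means among the compounds named here.

Series notes, values in a functional assay on HeLa cells (Homo sapiens) for antiproliferative activity, read by MTT assay, with a stated time of 72 h; on this read-out lower numbers stand for stronger inhibition and higher numbers for weaker inhibition:

- compound 1 `O=C1O[C@H]([C@@H](O)Cn2cc(-c3cc(C(F)(F)F)cc(C(F)(F)F)c3)nn2)C(OCc2ccccc2)=C1OCc1ccccc1`: 35500 nM
- compound 2 `CCCCCc1ccc(-c2cn(C/C=C3\OC(=O)C(OCc4ccccc4)=C3OCc3ccccc3)nn2)cc1`: > 100000 nM (a limit of the assay)
- compound 3 `CCCCc1cn(C[C@H](O)[C@H]2OC(=O)C(OCc3ccccc3)=C2OCc2ccccc2)nn1`: 18100 nM

Only two of these entries are numbers. Compound 3 at 18100 nM and compound 1 at 35500 nM lie within the usual scatter of each other, so the two cannot be ranked. The entry for compound 2 is a limit and not a number.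

The next compound to be tested is compound 4 `CC(C)(C)c1cn(C[C@H](O)[C@H]2OC(=O)C(OCc3ccccc3)=C2OCc2ccccc2)nn1`. It keeps the core of compound 3 and has the same atoms joined differently, with tert-butyl in place of butyl on an aromatic carbon of a five-membered aromatic ring with 3 nitrogen: tert-butyl in place of butyl on an aromatic carbon.

Going by the values given here, no measured pair shows this change, so the expectation starts from compound 3 at 18100 nM. The expected step in this assay, a 1.5-fold higher number from compound 3 to compound 4 (0.19 log units; within the scatter), is small and is not expected to exceed the scatter, with any shift more likely towards a higher number than a lower one. A limit rather than a number remains possible for this measurement.

The estimated value for compound 4 is 28000 nM, with an expected range of 10000 nM to 80000 nM.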

Compound 4, half-maximal inhibitory concentration: 18300 nM
For compound 4 the middle estimate is 1.5-fold (0.18 log units) above the measured one; the measured number falls inside the stated range.
By their numbers in this assay, from the lowest: compounds 3, 4 and 1 (each within the scatter of the next). At a limit, above all of these: compound 2.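

In this assay, going by these compounds alone, butyl and tert-butyl on this aromatic carbon of the five-membered aromatic ring with 3 nitrogen give a 1.0-fold higher number from compound 3 to compound 4 (0.00 log units; within the scatter), the first step that can be read between compounds differing in one place. At this position, with the rest of the molecule unchanged, rejoining the same atoms from the straight chain to the branched group leaves the number where it was, so this assay does not separate the two groups. Nothing given here accounts for this lack of separation.

On these data alone, what remains open is whether any group on this carbon can move the number beyond the scatter, since both groups here are small saturated hydrocarbon groups; a longer chain such as octyl, a primary amine or a carboxylic acid in the same place would be a sharper test of the position. The value of compound 2, > 100000 nM, is a limit of the assay, and no step can be read from compound 1 or compound 2 to the other compounds, as each differs from them in more than one place.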